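This account rests on a few compounds, and the source may have more. Where it says the series, first, only, none or still open, it means among the compounds named here.

Measured compounds:
compound 1 `O=C(O)C[C@@](O)(C(=O)O)[C@@H](Cl)C(=O)O` — 29000 nM
compound 2 `CS[C@H](C(=O)O)[C@@](O)(CC(=O)O)C(=O)O` — 34000 nM
compound 3 `O=C1C[C@@](C(=O)O)([C@@H](Cl)C(=O)O)O1` — 340000 nM

In an assay on isolated protein with ATP-citrate synthase (Rattus norvegicus) as the target (a higher number here means a weaker inhibitor, a lower number a stronger inhibitor), compound 1 gives 29000 nM. Compound 2 gives 34000 nM, which lies within the scatter of compound 1, so no order between these two can be read. Compound 3 gives 340000 nM, clearly higher and beyond the scatter. Among the measured compounds shown here, no two measured compounds differ in a single place, so no step size has yet been measured directly.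

Compound 4 `O=C(O)C[C@@](O)(C(=O)O)[C@@H](S)C(=O)O` is the next one to be measured in this assay. It differs from compound 1 by sulfanyl in place of chloro on a saturated chain carbon bound to a carbonyl carbon and a saturated chain carbon. Compound 2 also carries a sulfur atom and gives 34000 nM, which suggests that a sulfur group here is tolerated about as well as chloro. The step from compound 1 to compound 4 is therefore expected to be small, a 1.0-fold higher number from compound 1 to compound 4 (0.01 log units; within the scatter), none beyond the scatter in either direction. Compound 4 is estimated at 30000 nM, with a range from 8000 nM to 120000 nM.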

Compound 4, inhibition constant: 150000 nM
For compound 4 the middle estimate is 5.0-fold (0.70 log units) below the measured one; the whole stated range lies below it.
By their numbers in this assay, from the lowest: compounds 1 and 2 (each within the scatter of the next); then compound 4; then compound 3.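

In this assay, among the compounds shown here, sulfanyl in place of chloro on a saturated chain carbon bound to a carbonyl carbon and a saturated chain carbon gives a 5.2-fold higher number from compound 1 to compound 4 (0.71 log units; beyond the scatter), the first step measured directly. This position therefore distinguishes between these two groups, with chloro giving the stronger inhibitor of the pair. No measurement at hand accounts for the step.

As far as these compounds go, how a fluoro, bromo, hydroxyl or amine group on this carbon would compare with chloro remains open. From the compounds shown here alone, whether any group here improves on chloro also remains open.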